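Amide swap on compound 2 in the growth assay

A few compounds are considered here, and "the series" means these few. Any claim that something is new, unique, unknown or untested is made for them only; others in the source may bear on it.

Measured in a functional assay on HCT-116 cells (Homo sapiens) for inhibition, read by sulforhodamine B assay, with a stated time of 2 days; a lower number here means a stronger inhibitor of growth, a higher number a weaker inhibitor of growth:
compound 1 `CC1=C(C(=O)Nc2cccc([N+](=O)[O-])c2)C(c2ccc(O)cc2O)NC(NCc2ccccc2)=N1`: > 100000 nM (a limit)
compound 2 `Cc1ccc(NC(=O)c2c(C)nc(S(=O)(=O)Cc3ccccc3)nc2-c2ccc(O)cc2O)cc1`: 23500 nM

Among the compounds with values here, compound 2 holds the only actual number in this small set. Compound 1 gives > 100000 nM, which is a limit of this assay and not a number.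

Next in line is compound 3 `Cc1nc(S(=O)(=O)Cc2ccccc2)nc(-c2ccc(O)cc2O)c1C(=O)Nc1cccc([N+](=O)[O-])c1`, with 3-nitrophenyl in place of 4-methylphenyl on an amide-type nitrogen. Within the data shown here, no measured step yet shows what this change does. The expectation therefore stays close to compound 2 at 23500 nM, with a small weakening in this assay that may not exceed the usual scatter. The expected change is a 1.3-fold higher number from compound 2 to compound 3 (0.11 log units; within the scatter). For compound 3 the estimated value is 30000 nM, with an expected range from 10000 nM to 90000 nM.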

Compound 3, concentration for 50% growth inhibition: 10900 nM
Compound 3: middle estimate off by 2.8-fold (0.44 log units), on the high side; measured number inside the range.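

In this assay, within the data shown here, this gives the first readable step at the amide-type nitrogen: 3-nitrophenyl in place of 4-methylphenyl produces a 2.2-fold lower number from compound 2 to compound 3 (0.33 log units; beyond the scatter). The group on this nitrogen therefore affects growth inhibition, although the step is modest and compound 3 at 10900 nM remains a weak inhibitor of growth. Nothing shown bears on why the number moves.

The two groups differ in both the substituent and where it sits on the ring, so this single step cannot separate those two changes. Open questions are whether 3-methylphenyl or 4-nitrophenyl would divide the step between them, and whether an amine or a carboxylic acid in place of the nitro group on the same ring would keep, extend or lose it.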